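A Hydroxy-Methoxy Swap on the Hydrazone Series Limit

The compounds below may be only part of what the source reports. "The series", "measured", "known", "first", "only" and "open" are said of these compounds alone.

Compound 1 `O=C(N/N=C/c1ccccc1O)c1cn(C2CC2)c2cc(N3CCNCC3)c(F)cc2c1=O`: <= 25000 nM, a limit
Compound 2 `COc1cc(/C=N/NC(=O)c2cn(C3CC3)c3cc(N4CCNCC4)c(F)cc3c2=O)cc(OC)c1OC`: <= 25000 nM, a limit

In a functional assay on L1210 cells (Mus musculus) for antiproliferative activity, read by MTT assay (on this read-out higher numbers stand for weaker inhibition and lower numbers for stronger inhibition), compound 2 gives <= 25000 nM, which is a limit and not a number. Nothing finer is known of its standing, and the data offer only (the limit of <= 25000 nM in this assay, at which 2 of the 2 values shown sit).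

Compound 3 `COc1ccc(/C=N/NC(=O)c2cn(C3CC3)c3cc(N4CCNCC4)c(F)cc3c2=O)cc1O` keeps the core of compound 2 and carries 3-hydroxy-4-methoxyphenyl in place of 3,4,5-trimethoxyphenyl on a carbon with a double bond to nitrogen.

Going by the values given here, the one measured step at this place, a step that the two limits leave unreadable from compound 1 to compound 2, also exchanges the group there, but it gives no guide to size or direction. The step expected in this assay, a step that the limit leaves unreadable from compound 2 to compound 3, is therefore a loose estimate, with no direction expected beyond the scatter. For compound 3 the estimate is 10000 nM, with an expected range from 2000 nM to 25000 nM.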

Compound 3, half-maximal inhibitory concentration: <= 25000 nM
Compound 3: only a limit was reported; the forecaster's own chance of this, stated with the estimate: 60%; the middle value does not contradict the limit.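

In this assay, going by these compounds alone, compound 3 gives <= 25000 nM as a limit and not a number, so no step among compound 1, compound 2 and compound 3 can be read. The compounds shown leave open how their three aryl groups rank against one another: the limit of <= 25000 nM in this assay, at which 3 of the 3 values shown sit.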